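A few compounds are considered here, and "the series" means these few. Any claim that something is new, unique, unknown or untested is made for them only; others in the source may bear on it.

Measured compounds:
compound 1 `C=CCn1c(=O)/c(=C\c2ccccc2Cl)[nH]c(=O)/c1=C\c1ccccc1OC` – 9200 nM
compound 2 `C=CCn1c(=O)/c(=C\c2cccc(Br)c2)[nH]c(=O)/c1=C\c1cccc(Br)c1` – "not active" (no number reported)

In a functional assay on NCI-H1975 cells (Homo sapiens) for cytotoxicity, read by CCK-8 assay, with a stated time of 72 h (on this read-out higher numbers stand for weaker inhibition and lower numbers for stronger inhibition), compound 1 gives 9200 nM, the only numerical value among these compounds. In this assay compound 2 is recorded as "not active" (no number reported), with no number reported. Compound 3 `C=CCn1c(=O)/c(=C\c2cc(F)ccc2C)[nH]c(=O)/c1=C\c1ccccc1OC` differs from compound 1 by 5-fluoro-2-methylphenyl in place of 2-chlorophenyl on a double-bonded chain carbon bound to an aromatic carbon. For the measured compounds named here, no measured pair shows how such a change acts in this assay, so the step from compound 1 to compound 3 is expected to be small, at most a modest weakening, a 1.3-fold higher number from compound 1 to compound 3 (0.12 log units; within the scatter). Compound 3 is therefore estimated at 12000 nM in this assay, within a range of 4000 nM to 40000 nM.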

Compound 3, half-maximal inhibitory concentration: 7300 nM
The estimate for compound 3 lay 1.6-fold (0.22 log units) above the measured number, and the stated range covers the measured number.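

In this assay, for the compounds shown here, 5-fluoro-2-methylphenyl in place of 2-chlorophenyl on a double-bonded chain carbon bound to an aromatic carbon gives the first step that can be read at this position (a 1.3-fold lower number from compound 1 to compound 3 (0.10 log units; within the scatter)). This position therefore accepts one substituted phenyl for the other with no change that can be told from the scatter. Nothing measured here bears on this result. From the compounds shown here alone, it remains open whether a group of another kind at this place, such as an aminophenyl or a carboxylic acid, would move the number beyond the scatter.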